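Working notes: from compound 3 to compound 4

This account rests on a few compounds, and the source may have more. Where it says the series, first, only, none or still open, it means among the compounds named here.

Measured in a functional assay on BMEC cells (Bos taurus) for antiproliferative activity; a lower number here means a stronger inhibitor, a higher number a weaker inhibitor:
- compound 1 `COc1cc(/C=C/Cc2cc(O)c3ccoc3c2)cc(OC)c1OC`: 27700 nM
- compound 2 `COc1cc(/C=C/Cc2cc(O)c3cc(-c4ccccc4)oc3c2)cc(OC)c1OC`: > 20000 nM (a limit)
- compound 3 `COc1cc(/C=C\Cc2cc(O)c3ccccc3c2)cc(OC)c1OC`: 670 nM

Compound 3 at 670 nM holds the lowest number in the series, and compound 1 at 27700 nM lies higher, beyond the scatter. Compound 2 gives > 20000 nM, which is a limit and not a number.

Compound 4 `COc1cc(/C=C/Cc2cc(O)c3ccccc3c2)cc(OC)c1OC` is next, with one change: the two compounds have the same atoms and bonds and differ only in configuration as drawn: 1 of 1 stereo elements differ; a double bond is drawn Z in compound 3 and E in compound 4.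

Among the compounds with values here, the only measured step is a step that the limit leaves unreadable from compound 1 to compound 2. It concerns a different change and gives no size to carry over. Within the data shown here, no measured pair isolates the double bond. The closest guide is compound 1 at 27700 nM, whose double bond is also drawn E, although its core differs from that of compound 3. A rise in the number, beyond the scatter, is therefore expected in this assay, and its size is uncertain. The expected step is a 13-fold higher number from compound 3 to compound 4 (1.13 log units; beyond the scatter). For compound 4 the estimated value is 9000 nM, with an expected range of 2000 nM to 30000 nM.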

Compound 4, half-maximal inhibitory concentration: 56400 nM
The estimate for compound 4 lay 6.3-fold (0.80 log units) below the measured number; the measured number lies above the stated range.
By their numbers in this assay, from the lowest: compound 3; then compound 1; then compound 4.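

In this assay, the configuration of the double bond alone carries a large change, with an 84-fold higher number from compound 3 to compound 4 (1.93 log units; beyond the scatter). This step can be assigned to the double bond and to nothing else because of one fact: the fact that compounds 3 and 4 differ only in the configuration as drawn. Within the data shown here, the only earlier step, the phenyl change, cannot be read, so this pair gives the first size for any change.

The compounds shown leave open whether the Z drawing would bring a comparable drop in the number on the core of compound 1. Also open, going by these compounds, is how an amine or a carboxylic acid on the shared core of compound 3 would change the number in this assay.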